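Swapping 1H-indol-6-yl for 4-methylthiophen-2-yl on a shared core

The source may report more compounds than this note shows. Statements on the series, on what has been measured and on what is new or still open speak of the compounds shown alone.

Measured so far in a toxicity assay on MT4 cells (Homo sapiens) for cytotoxicity, read by MTT assay, with a stated time of 5 days; on this read-out lower numbers stand for higher toxicity in this test and higher numbers for lower toxicity in this test:
- compound 1 `Cc1cc(-c2cccc3cc[nH]c23)cc(C)c1Nc1ccnc(Nc2ccc(C#N)cc2)n1`: 1000 nM
- compound 2 `Cc1cc(-c2ccc3cc[nH]c3c2)cc(C)c1Nc1ccnc(Nc2ccc(C#N)cc2)n1`: 5800 nM

Compound 2 stands highest of the two, at 5800 nM, so it is the less toxic of the pair in this assay. The next compound to be tested, compound 3 `Cc1csc(-c2cc(C)c(Nc3ccnc(Nc4ccc(C#N)cc4)n3)c(C)c2)c1`, keeps the shared core but carries 4-methylthiophen-2-yl in place of 1H-indol-6-yl. The exchange happens on an aromatic carbon of a six-membered aromatic ring of carbon only, meta to two methyl groups and para to a large group (4-methylthiophen-2-yl in place of 1H-indol-6-yl on an aromatic carbon).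

Among the compounds with values here, only one measured step offers any guide. Putting 1H-indol-6-yl in place of 1H-indol-7-yl gave a 5.8-fold higher number from compound 1 to compound 2 (0.76 log units; beyond the scatter). That step shows that a change at this place can shift the number modestly. Within the data shown here, no measured compound carries 4-methylthiophen-2-yl, however, so the guide is a loose one. With compound 2 at the top of a narrow measured range, a smaller step towards a lower number is expected in this assay. The expected change is a 2.3-fold lower number from compound 2 to compound 3 (0.37 log units; beyond the scatter). For compound 3 the estimated value is 2500 nM, with an expected range from 700 nM to 9000 nM.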

Compound 3, half-maximal cytotoxic concentration: 34000 nM
Compound 3: the middle estimate sits 14-fold (1.13 log units) below what was measured; measured number above the stated range.
By their numbers in this assay, from the lowest: compound 1; then compound 2; then compound 3.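

In this assay, replacing an indole with 4-methylthiophen-2-yl gives a 5.9-fold higher number from compound 2 to compound 3 (0.77 log units; beyond the scatter) and a 34-fold higher number from compound 1 to compound 3 (1.53 log units; beyond the scatter), making compound 3 the least toxic of the three in this test. The earlier pair showed only that moving the attachment point of an indole could shift the number; these steps show that exchanging the indole for a different group with fewer heavy atoms, on the same aromatic carbon, can shift it further. No measurement here accounts for the higher number, so the result describes what happened at this position without explaining it.

The entering group differs from the indoles in several ways at once: it has one five-membered ring rather than two fused rings, a sulfur rather than a nitrogen, a methyl group, and no hydrogen-bond donor, and these three compounds cannot show which of these differences matters. Comparing the same core carrying an unsubstituted thiophen-2-yl, a plain phenyl or an aminophenyl group at this carbon would help separate them.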